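The source may hold more compounds than are shown below. What is called first, only, known or untested is meant among the compounds shown, and "the series" means these compounds.

Compound 1 `COC(=O)/C=C/c1cccc(N(Cc2ccc(-c3ccc(F)c(F)c3)cc2)C(=O)C2CCCCC2)c1` gives 72 nM in an assay on isolated protein with Bile acid receptor (Homo sapiens) as the target; on this read-out lower numbers stand for an effect already at smaller amounts and higher numbers for an effect only at larger amounts of compound. Going by the values given here, compound 2 `COC(=O)/C=C/c1cccc(N(Cc2ccc(-c3ccc(OC)cc3)cc2)C(=O)C2CCCCC2)c1` gives 89 nM in this assay, the highest of the two numbers so far, separated from the nearest only by a 1.2-fold higher number from compound 1 to compound 2 (0.09 log units; within the scatter). Compound 3 `COC(=O)/C=C/c1cccc(N(Cc2ccc(-c3cccc(C)c3)cc2)C(=O)C2CCCCC2)c1` differs from compound 2 by 3-methylphenyl in place of 4-methoxyphenyl on an aromatic carbon. Among the compounds with values here, the one step already made at this position, a 1.2-fold higher number from compound 1 to compound 2 (0.09 log units; within the scatter), stayed within the scatter, so the step of a 1.0-fold lower number from compound 2 to compound 3 (0.02 log units; within the scatter) is expected to stay within the scatter as well, with no direction claimed. For compound 3 the estimate in this assay is 85 nM, with a range from 40 nM to 180 nM.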

Compound 3, half-maximal effective concentration: 109 nM
Estimate against measurement, compound 3: 1.3-fold (0.11 log units) below, and the stated range covers the measured number.
By their numbers in this assay, from the lowest: compounds 1, 2 and 3 (each within the scatter of the next).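

In this assay, the aromatic carbon para to a large group now carries a third group, and both new steps stay within the scatter (a 1.2-fold higher number from compound 2 to compound 3 (0.09 log units; within the scatter); a 1.5-fold higher number from compound 1 to compound 3 (0.18 log units; within the scatter)). 3-Methylphenyl has no hydrogen-bond acceptor, whereas 4-methoxyphenyl has one, so losing that acceptor gives no step beyond the scatter here.

Still open, going by these compounds, is whether a phenyl group bearing an amine or a carboxylic acid at this position would stay within the scatter. No measurement at hand gives a reason for these values.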